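Aryl amine variation: from compound 2 to compound 4

The compounds below may be only part of what the source reports. "The series", "measured", "known", "first", "only" and "open" are said of these compounds alone.

Three compounds with a shared core and differing aryl groups on the ring nitrogen have been run in a functional assay on MCF7 cells (Homo sapiens) for cytotoxicity, read by sulforhodamine B assay, with a stated time of 72 h; on this read-out higher numbers stand for weaker inhibition and lower numbers for stronger inhibition. Compound 1 `CCS(=O)(=O)Nc1cc(-c2ccc3ncnc(Nc4ccc(F)cc4)c3c2)cnc1OC` gives 6510 nM. Compound 2 `CCS(=O)(=O)Nc1cc(-c2ccc3ncnc(Nc4ccc(OC(F)(F)F)cc4)c3c2)cnc1OC` gives 23700 nM, the highest number of the three. Compound 3 `CCS(=O)(=O)Nc1cc(-c2ccc3ncnc(Nc4ccc(OC)c(OC)c4)c3c2)cnc1OC` gives 2430 nM, the lowest. The measured steps are a 3.6-fold higher number from compound 1 to compound 2 (0.56 log units; beyond the scatter), a 2.7-fold lower number from compound 1 to compound 3 (0.43 log units; beyond the scatter) and a 9.8-fold lower number from compound 2 to compound 3 (0.99 log units; beyond the scatter).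

Compound 4 `CCS(=O)(=O)Nc1cc(-c2ccc3ncnc(Nc4ccc(F)c(C(=O)OC)c4)c3c2)cnc1OC` is not yet measured in this assay. Relative to compound 2 the change is 4-fluoro-3-(methoxycarbonyl)phenyl in place of 4-(trifluoromethoxy)phenyl on a nitrogen on an aromatic ring. Among the measured compounds shown here, two measured steps bear on it. The step of a 3.6-fold higher number from compound 1 to compound 2 (0.56 log units; beyond the scatter) shows that replacing fluoro with trifluoromethoxy raised the number; compound 4 reverses that part, carrying fluoro again, and adds methoxycarbonyl. The step of a 9.8-fold lower number from compound 2 to compound 3 (0.99 log units; beyond the scatter) shows that swapping the 4-(trifluoromethoxy)phenyl for a differently substituted phenyl lowered the number by a larger margin. For the measured compounds named here, no measured compound carries a methoxycarbonyl group, so that part of the change has no precedent here.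

The expectation for compound 4 in this assay is therefore a modest step downward, about the size seen from compound 1 to compound 2 in reverse, stated as a 4.3-fold lower number from compound 2 to compound 4 (0.63 log units; beyond the scatter). Compound 4 is estimated at 5500 nM, with a range from 1500 nM to 18000 nM.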

Compound 4, half-maximal inhibitory concentration: 1150 nM
For compound 4 the middle estimate is 4.8-fold (0.68 log units) above the measured one, outside the stated range (below it).
By their numbers in this assay, from the lowest: compound 4; then compound 3; then compound 1; then compound 2.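

In this assay, methoxycarbonyl added to the fluorophenyl ring of compound 1 gives a 5.7-fold lower number from compound 1 to compound 4 (0.75 log units; beyond the scatter) and the lowest number of the four compounds, so a substituent added to this aryl group, with the fluoro retained, can lower the number. Among the compounds shown here, the change from 4-(trifluoromethoxy)phenyl to 4-fluoro-3-(methoxycarbonyl)phenyl gives a 21-fold lower number from compound 2 to compound 4 (1.31 log units; beyond the scatter) and is the only step graded large, which widens the span seen at this nitrogen-linked aryl group. The further step of a 2.1-fold lower number from compound 3 to compound 4 (0.32 log units; beyond the scatter) shows that 3,4-dimethoxyphenyl is not the best of these aryl groups in this read-out, and both aryl groups carrying two substituents give lower numbers than the two carrying one, a pattern that rests on these four compounds alone.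

No supporting measurement is available to explain these steps. As far as these compounds go, it remains open whether methoxycarbonyl itself carries the effect, or whether the pairing with fluoro matters; a carboxylic acid or a primary amide in place of methoxycarbonyl, and methoxycarbonyl on a ring without the fluoro, would separate these readings.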